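The source may hold more compounds than are shown below. What is called first, only, known or untested is meant among the compounds shown, and "the series" means these compounds.

Two compounds of the series have been through an assay on nucleic acid for inhibition of Nucleic Acid, read by fluorescence, tested at 100 uM; a higher number here means more inhibition at the concentration tested (going by the name of the read-out), a lower number less inhibition. Compound 1 `CN(Cc1cn(CC(O)COC(=O)C2CCCCC2)nn1)CC1CCCCC1` gives 18% in this assay. Compound 2 `CCCCNC(=O)OCC(O)Cn1cc(CN(C)CCC(C)C)nn1` gives 24% in this assay, a number within the usual scatter of the reading for compound 1, so the two cannot be ranked on what is at hand. Within the data shown here, compound 1 and compound 2 differ at more than one place and no single step between them is laid out; their two values simply stand side by side. Compound 3 `CCCCNC(=O)OCC(O)Cn1cc(CN(C)CC2CCCCC2)nn1` is not yet measured in this assay. It differs from compound 2 by cyclohexyl in place of isobutyl on a saturated chain carbon bound to an amine nitrogen. The (cyclohexylmethyl)(methyl)amino group that enters is already present in compound 1, which gave 18% with a different ester part. The expected step is a number 2 percentage points lower from compound 2 to compound 3 (within the scatter), none beyond the scatter. The estimate for compound 3 in this assay is 22%, expected to fall within 10% to 34%.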

Compound 3, a percentage reported as inhibition, at one concentration (the size of the read-out at that concentration, not a potency): 12%
The estimate for compound 3 lay 10 percentage points above the measured number; low and high end bracket the measured number.
By their numbers in this assay, from the lowest: compounds 3, 1 and 2 (each within the scatter of the next, the first and the last beyond it).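

In this assay, among these compounds, the amine side chain gives the first step that clears the scatter: cyclohexyl in place of isobutyl on a saturated chain carbon bound to an amine nitrogen gives a number 12 percentage points lower from compound 2 to compound 3 (beyond the scatter) and so counts as a modest loss at this position. With the (cyclohexylmethyl)(methyl)amino group held constant, butylamino in place of cyclohexyl on a carbonyl carbon gives a number 6 percentage points lower from compound 1 to compound 3 (within the scatter) and so cannot be told from the scatter. Nothing at hand bears on what lies behind the loss.

As far as these compounds go, whether a phenyl ring or a straight hexyl chain at this place would read like cyclohexyl or like isobutyl remains open, so the ring and the larger size of the group cannot yet be separated. Also open, from the compounds shown here alone, is whether isobutyl would keep its edge over cyclohexyl with the cyclohexyl carbonyl part of compound 1.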